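Cationic chain terminus exchange in a quinolone amide series

A few compounds are considered here, and "the series" means these few. Any claim that something is new, unique, unknown or untested is made for them only; others in the source may bear on it.

Four compounds share a core built around the quinolone amide of compound 1 `CN(C)c1ccc2c(=O)c(C(=O)Nc3cc(F)cc(F)c3)cn(-c3ccc(OCCCCCCC[n+]4ccccc4)c(Cl)c3)c2n1`, compound 2 `Cc1ccc(-n2cc(C(=O)Nc3cc(F)cc(F)c3)c(=O)c3ccc(N(C)C)nc32)cc1OCCCCCCC[n+]1ccccc1`, compound 3 `CN1CC[N+](C)(CCCCCCCOc2ccc(-n3cc(C(=O)Nc4cc(F)cc(F)c4)c(=O)c4ccc(N(C)C)nc43)cc2Cl)CC1` and compound 4 `Cc1ccc(-n2cc(C(=O)Nc3cc(F)cc(F)c3)c(=O)c3ccc(N(C)C)nc32)cc1OCCCCCCC[N+]1(C)CCN(C)CC1`. The difference between the core of compound 1 and the core of compound 2 is not broken down here. In an assay on LX2 cells for inhibition of COL1A1 promoter (Homo sapiens), read by a luciferase reporter, with a stated time of 24 h, tested at 50 uM (a lower number here means a weaker effect, a higher number a stronger effect of the compound at the concentration tested), compound 1 gives 21.4%, compound 2 gives 22.2% and compound 3 gives 15.4%; the values of compound 1 and compound 2 lie within the usual scatter of each other, as do those of compound 2 and compound 3.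

One structural change is seen twice. From compound 1 to compound 3 it is a group of 8 heavy atoms (6 carbon, 2 nitrogen; one six-membered non-aromatic ring with 2 hetero atoms) in place of a group of 6 heavy atoms (5 carbon, 1 nitrogen; one six-membered aromatic ring with 1 hetero atom), on a saturated chain carbon, seven bonds along the chain from an oxygen on an aromatic ring, and the measured step in this assay is a number 6 percentage points lower from compound 1 to compound 3 (within the scatter). From compound 2 to compound 4 the same change is made, (a group of 8 heavy atoms (6 carbon, 2 nitrogen; one six-membered non-aromatic ring with 2 hetero atoms) in place of a group of 6 heavy atoms (5 carbon, 1 nitrogen; one six-membered aromatic ring with 1 hetero atom), on a saturated chain carbon, seven bonds along the chain from an oxygen on an aromatic ring), at a place described in the same words. Compound 4 is not yet measured in this assay.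

For the measured compounds named here, since the only measured example of this change left the read-out within the scatter, the step from compound 2 to compound 4 in this assay is expected to be small as well, estimated at a number 6.2 percentage points lower from compound 2 to compound 4 (within the scatter), because the step from compound 1 to compound 3 was a number 6 percentage points lower from compound 1 to compound 3 (within the scatter). Going by the values given here, with only one precedent the direction is uncertain, so the range is kept wide. For compound 4 in this assay the expected value is 16%, between 6% and 26%.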

Compound 4, a percentage reported as inhibition, at one concentration (the size of the read-out at that concentration, not a potency): 25%
For compound 4 the middle estimate is 9 percentage points below the measured one, within the range that was stated.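

In this assay, replacing the six-membered aromatic ring group with one hetero atom by the six-membered non-aromatic ring group with 2 hetero atoms, on a saturated chain carbon seven bonds along the chain from an oxygen on an aromatic ring, gives a number 2.8 percentage points higher from compound 2 to compound 4 (within the scatter). Set beside the earlier step, the change carries from one core to the other without a difference that these measurements can resolve: the same change on two cores in this assay, a number 6 percentage points lower (within the scatter) from compound 1 to compound 3 and a number 2.8 percentage points higher (within the scatter) from compound 2 to compound 4, 8.8 percentage points apart, within the scatter of two such steps. This shows that neither core gives a read-out that separates the two chain-end groups at the single concentration tested; it does not show that the two cores respond identically, that the steps truly differ in direction, or that either group leaves the effect at that concentration unchanged, and two pairs are too few to make a rule of it.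

The compounds shown leave open whether a morpholine ring, a piperidine ring or a simple trimethylammonium group at the end of the chain would give a read-out that stands clear of the scatter. They also leave open how a shorter or longer chain would behave on either core, and whether concentration-response data would separate any of these compounds.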